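Replacing the ring on compound 2 with an open-chain oxime ether

The source may hold more compounds than are shown below. What is called first, only, known or untested is meant among the compounds shown, and "the series" means these compounds.

Compound 1, `c1coc(-c2ccccc2NCC2=NCCN2)c1`: 6.31 nM in a functional assay for activation of Alpha-1B adrenergic receptor (Homo sapiens), read by calcium flux; on this read-out higher numbers stand for an effect only at larger amounts of compound and lower numbers for an effect already at smaller amounts.
Compound 2, `Cc1ncc(-c2ccccc2NCC2=NCCN2)o1`: in this assay compound 2 gives only a limit, < 5020 nM.
Compound 3, `c1ccc(-c2cnoc2)c(NCC2=NCCN2)c1`: in this assay compound 3 likewise gives only a limit, < 100000 nM.

On these numbers compound 2 stands nowhere definite: its result is a limit, not a value, and the result of compound 3 is a limit as well. Only compound 1 has a measured number. The step from compound 1 to compound 2 a step that the limit leaves unreadable from compound 1 to compound 2 cannot be sized because compound 2 sits at the limit of < 5020 nM in this assay, at which 1 of the 3 values shown sits. The step from compound 1 to compound 3 a step that the limit leaves unreadable from compound 1 to compound 3 is unreadable in the same way, and the step from compound 2 to compound 3 a step that the two limits leave unreadable from compound 2 to compound 3 is closed off by both limits.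

Compound 4, `CO/N=C(\C)c1ccccc1NCC1=NCCN1`, differs from compound 2 by a group of 5 heavy atoms (3 carbon, 1 nitrogen, 1 oxygen; no ring) in place of a group of 6 heavy atoms (4 carbon, 1 nitrogen, 1 oxygen; one five-membered aromatic ring with 2 hetero atoms), on an aromatic carbon. Among the compounds with values here, no measured step bears on this change, so no direction can be read from the steps; the only anchor is that compound 2 is somewhere below its limit and compound 1 is potent. Compound 4 is therefore expected to land near 200 nM, within a wide range from 10 nM to 5000 nM, a step from compound 2 estimated as a step that the limit leaves unreadable from compound 2 to compound 4.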

Compound 4, half-maximal effective concentration: < 5020 nM
Compound 4: only a limit was reported; the forecaster's own chance of this, stated with the estimate: 25%; the middle value is on the limit's open side.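

In this assay compound 4 gives only a limit (< 5020 nM). Within the data shown here, none of the steps joining compound 4 to compound 1, compound 2 or compound 3 can be read, so this result adds no new step. The compounds shown leave open where compound 2, compound 3 and compound 4 actually stand relative to compound 1, the only one with a measured number.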